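A few compounds are considered here, and "the series" means these few. Any claim that something is new, unique, unknown or untested is made for them only; others in the source may bear on it.

In a functional assay on HeLa cells (Homo sapiens) for cytotoxicity, read by MTT assay, with a stated time of 24 h (a higher number here means a weaker inhibitor, a lower number a stronger inhibitor), three compounds have been measured so far. For compound 1 `Cc1cc2ccccc2nc1-c1cn(CCC(F)(F)C(F)(F)C(F)(F)C(F)(F)C(F)(F)C(F)(F)C(F)(F)C(F)(F)F)nn1` the result is a limit of the assay, > 100 ug/mL. Compound 3 `CCc1cc2ccccc2nc1-c1cn(CCC(F)(F)C(F)(F)C(F)(F)C(F)(F)C(F)(F)C(F)(F)C(F)(F)C(F)(F)F)nn1` differs from compound 1 by methyl in place of hydrogen on a saturated chain carbon bound to an aromatic carbon. For compound 3 the result is likewise a limit, > 100 ug/mL. The step that the two limits leave unreadable from compound 1 to compound 3 therefore cannot be read, because of the limit of > 100 ug/mL in this assay, at which 3 of the 3 values shown sit. Compound 2 `CCCc1cc2ccccc2nc1-c1cn(-c2ccc(F)cc2)nn1` rests on a different core, and the difference between the two cores is not broken down here. For compound 2 the result is again a limit, > 100 ug/mL. Compound 4 `CCCCc1cc2ccccc2nc1-c1cn(-c2ccc(F)cc2)nn1` has not yet been measured; it differs from compound 2 by methyl in place of hydrogen on a saturated chain carbon, three bonds along the chain from an aromatic carbon. This is the same kind of change as that from compound 1 to compound 3, but the place differs: there the saturated chain carbon is bound to an aromatic carbon, here it lies three bonds along the chain from an aromatic carbon. The expected size of the step is a step that the limit leaves unreadable from compound 2 to compound 4, since compound 2 gives > 100 ug/mL and (the limit of > 100 ug/mL in this assay, at which 3 of the 3 values shown sit). Compound 4 is therefore expected to give 120 ug/mL, somewhere between 50 ug/mL and 300 ug/mL.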

Compound 4, half-maximal inhibitory concentration: > 100 ug/mL
Compound 4 ended at the assay's limit; the forecaster's own chance of this, stated with the estimate: 80%; the middle value is on the limit's open side.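

For the compounds shown here, compound 2 and compound 4 each sit at a limit of this assay rather than at a number, so no step from one to the other can be read: (the limit of > 100 ug/mL in this assay, at which 4 of the 4 values shown sit). The compounds shown leave open what real potency any of the four has, and whether methyl in place of hydrogen shifts it at all.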